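A few compounds are considered here, and "the series" means these few. Any claim that something is new, unique, unknown or untested is made for them only; others in the source may bear on it.

Measured so far in a functional assay on DU-145 cells (Homo sapiens) for inhibition, read by trypan blue exclusion, with a stated time of 96 h; a higher number here means a weaker inhibitor of growth, a lower number a stronger inhibitor of growth:

Compound 1 (`O=C(/C(=C\c1c[nH]c2ccccc12)Sc1ccc(Br)cc1)c1ccc(Br)cc1`) gives 1000 nM
Compound 2 (`COc1ccc(/C=C(\C(=O)c2ccc(Br)cc2)S(=O)(=O)c2ccc(C)cc2)cc1`) gives 1000 nM

Compound 2 stands level with compound 1 at the digits shown, so neither can be called the better inhibitor of growth. The two differ in more than one place, so they do not isolate any single change. Compound 3 (`Cc1ccc(S(=O)(=O)/C(=C/c2c[nH]c3ccccc23)C(=O)c2ccc(Br)cc2)cc1`) has not yet been measured, and it differs from compound 2 in one place: 1H-indol-3-yl in place of 4-methoxyphenyl on a double-bonded chain carbon bound to a double-bonded chain carbon. Put simply, 1H-indol-3-yl replaces 4-methoxyphenyl on a double-bonded chain carbon bound to a double-bonded chain carbon. Among the measured compounds shown here, no measured pair tests this swap on its own, so any expectation is loose. For the measured compounds named here, the only hint is that compound 1 also carries 1H-indol-3-yl and gives 1000 nM in this assay, level with compound 2 at 1000 nM in the same test. No change beyond the scatter is therefore expected, in either direction. The expected step is a 1.4-fold lower number from compound 2 to compound 3 (0.15 log units; within the scatter) and it stays within that scatter. Compound 3 is estimated at 700 nM with a likely range from 150 nM to 3000 nM once it is measured.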

Compound 3, concentration for 50% growth inhibition: 10000 nM
The estimate for compound 3 lay 14-fold (1.15 log units) below the measured number, and the stated range ends below it.
By their numbers in this assay, from the lowest: compounds 1 and 2 (each within the scatter of the next); then compound 3.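

In this assay, placing 1H-indol-3-yl where 4-methoxyphenyl sat, on a double-bonded chain carbon bound to a double-bonded chain carbon, brings a 10-fold higher number from compound 2 to compound 3 (1.00 log units; beyond the scatter) at this position, so the swap is not neutral when (4-methylphenyl)sulfonyl is present. With 1H-indol-3-yl held in place, (4-methylphenyl)sulfonyl in place of (4-bromophenyl)sulfanyl brings a 10-fold higher number from compound 1 to compound 3 (1.00 log units; beyond the scatter) in the same test. Compound 1 also carries 1H-indol-3-yl, so that group alone does not go with the higher number; among these compounds, the higher number appears only in compound 3, where 1H-indol-3-yl and (4-methylphenyl)sulfonyl occur together.

No supporting measurement explains either rise in the number. Still open, going by these compounds, is whether a 4-aminophenyl group at the place of the first swap would stay level with compound 2 or move like compound 3, and whether a (4-bromophenyl)sulfonyl group would behave like the (4-methylphenyl)sulfonyl group of compound 3.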